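Swapping Benzyloxy for Methylsulfonyl in a Cytotoxicity Series

This account rests on a few compounds, and the source may have more. Where it says the series, first, only, none or still open, it means among the compounds named here.

Compound 1, `CC(C)N(Cc1cccc(OCCCCCC(=O)O)c1)C(=O)c1ccc(-c2ccncc2)cc1`: > 26000 nM
Compound 2, `CC(C)N(Cc1cccc(OCCCCCC(=O)O)c1)C(=O)c1ccc(-c2cccc(OCc3ccccc3)c2)cc1`: > 26000 nM

Both compounds were tested in an ADME assay on HEK293 cells (Homo sapiens) for cytotoxicity, read by CellTiter-Glo and resazurin assay, with a stated time of 72 h; a lower number here means that less compound is needed, a higher number that more compound is needed for the effect. For compound 1 the value > 26000 nM is a limit of the assay, not a number. For compound 2 the value > 26000 nM is likewise a limit. Compound 2 thus stands at the limit of > 26000 nM in this assay, at which 2 of the 2 values shown sit. Among the measured compounds shown here, since no number was reached for either compound, neither can be ranked against the other, and there is no measured step to draw on.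

Compound 3, `CC(C)N(Cc1cccc(OCCCCCC(=O)O)c1)C(=O)c1ccc(-c2cccc(S(C)(=O)=O)c2)cc1`, has not yet been measured. It differs from compound 2 in a single place: methylsulfonyl in place of benzyloxy on an aromatic carbon. Both compounds made so far are cytotoxic only beyond the reach of this assay, which gives no basis for predicting a shift. The step that the limit leaves unreadable from compound 2 to compound 3 is therefore expected to be none beyond the usual scatter. In this assay compound 3 is expected to give about 30000 nM, with a plausible range from 15000 nM to 60000 nM, and it would most likely again be reported as a limit rather than a number.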

Compound 3, half-maximal effective concentration: > 26000 nM
Compound 3 gave a limit, no number (the forecaster's own chance of this, stated with the estimate: 80%); the middle value does not contradict the limit.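

No new step can be read, since compound 1, compound 2 and compound 3 all end at the same limit rather than at a number, so swapping the groups gives no size of change: the limit of > 26000 nM in this assay, at which 3 of the 3 values shown sit.

The compounds shown leave open at what concentration, if any, each of them would harm these cells in this assay.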